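This account rests on a few compounds, and the source may have more. Where it says the series, first, only, none or still open, it means among the compounds named here.

In a functional assay on HeLa cells (Homo sapiens) for inhibition (a lower number here means a stronger inhibitor, a higher number a weaker inhibitor), compound 1 `Cc1cn(/C=C/C=O)c(=O)[nH]c1=O` gives 23000 nM and compound 2 `O=C/C=C/n1cc(F)c(=O)[nH]c1=O` gives 60000 nM while compound 3 `O=C/C=C/n1cc(C(F)(F)F)c(=O)[nH]c1=O` gives 60000 nM and so stands level with compound 2, both with a higher number than compound 1. Among the compounds with values here, compound 4 `O=C/C=C/n1cc(CO)c(=O)[nH]c1=O` carries hydroxymethyl in place of trifluoromethyl on an aromatic carbon and no measured compound holds that group. Three measured steps at this carbon bear on it: fluoro in place of methyl gave a 2.6-fold higher number from compound 1 to compound 2 (0.42 log units; beyond the scatter) and trifluoromethyl in place of methyl gave a 2.6-fold higher number from compound 1 to compound 3 (0.42 log units; beyond the scatter) while trifluoromethyl in place of fluoro gave no change at the digits printed from compound 2 to compound 3 (within the scatter) and so the swaps seen so far are small. A small move toward a lower number is therefore expected (a 1.5-fold lower number from compound 3 to compound 4 (0.18 log units; within the scatter)). Compound 4 is estimated at 40000 nM (from 15000 nM to 90000 nM).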

Compound 4, half-maximal inhibitory concentration: > 100000 nM
Compound 4: only a limit was reported (the forecaster's own chance of this, stated with the estimate: 10%); middle value at least 2.5-fold (0.39 log units) from the limit.
By their numbers in this assay, from the lowest: compound 1; then compounds 2 and 3 (each within the scatter of the next). At a limit, above all of these: compound 4.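

Compound 4 gives only a limit in this assay: the limit of > 100000 nM in this assay, at which 1 of the 4 values shown sits.

Hydroxymethyl in place of methyl gives an at least 4.3-fold higher number from compound 1 to compound 4 (0.63 log units; beyond the scatter), so this group, with its hydrogen-bond donor and acceptor, does not bring the number down, and methyl keeps the lowest number of the four groups. Against the two fluorinated groups the steps are an at least 1.6-fold higher number from compound 3 to compound 4 (0.22 log units; that floor lies within the scatter) and an at least 1.6-fold higher number from compound 2 to compound 4 (0.22 log units; that floor lies within the scatter), so these floors alone do not separate hydroxymethyl from them.

As far as these compounds go, how far compound 4 truly lies past its limit stays open. So does whether an amine, a carboxylic acid or a longer chain at this carbon would reach a lower number than methyl.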